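Swapping the Aryl Group on a Shared Core

The source may report more compounds than this note shows. Statements on the series, on what has been measured and on what is new or still open speak of the compounds shown alone.

Three compounds have so far been measured in a functional assay on NCI-H460 cells (Homo sapiens) for inhibition, read by sulforhodamine B assay, with a stated time of 48 h; a lower number here means a stronger inhibitor of growth, a higher number a weaker inhibitor of growth:

compound 1 `CC1=CC[C@H](C(C)(C)NC(=S)N/N=C/c2ccccc2)CC1`: 13000 nM
compound 2 `CC1=CC[C@H](C(C)(C)NC(=S)N/N=C/c2ccccc2Cl)CC1`: 64500 nM
compound 3 `CC1=CC[C@H](C(C)(C)NC(=S)N/N=C/c2ccc(Cl)cc2)CC1`: 7800 nM

Compound 3 has the lowest of the three numbers. The step of a 1.7-fold lower number from compound 1 to compound 3 (0.22 log units; within the scatter) is within the scatter, so compound 1 and compound 3 cannot be told apart; the step of an 8.3-fold lower number from compound 2 to compound 3 (0.92 log units; beyond the scatter) is beyond the scatter and is the only clear separation among the three.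

Compound 4 `CC1=CC[C@H](C(C)(C)NC(=S)N/N=C/c2cccs2)CC1` differs from compound 3 in one place: thiophen-2-yl in place of 4-chlorophenyl on a carbon with a double bond to nitrogen. The measured steps that touch this position are the two chloro additions, a 5.0-fold higher number from compound 1 to compound 2 (0.70 log units; beyond the scatter) and a 1.7-fold lower number from compound 1 to compound 3 (0.22 log units; within the scatter), and the move of chloro around the ring, an 8.3-fold lower number from compound 2 to compound 3 (0.92 log units; beyond the scatter). None of them exchanges the ring itself, so they bear on compound 4 only loosely. The new ring carries no chloro, which makes compound 1 the nearest measured analogue, and compound 1 stands within the scatter of compound 3. The expected change in this assay is therefore small, towards a slightly higher number, and probably within the scatter, as the step of a 1.5-fold higher number from compound 3 to compound 4 (0.19 log units; within the scatter) expresses.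

Compound 4 is estimated at 12000 nM, with a range from 4000 nM to 40000 nM.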

Compound 4, concentration for 50% growth inhibition: 10800 nM
The estimate for compound 4 lay 1.1-fold (0.05 log units) above the measured number; measured number inside the range.
By their numbers in this assay, from the lowest: compounds 3, 4 and 1 (each within the scatter of the next); then compound 2.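

Until now, the carbon with a double bond to nitrogen had carried only a phenyl ring, with or without chloro. Compound 4 shows that a five-membered aromatic ring containing sulfur can take this place in this assay and still not be told apart from either phenyl (unsubstituted: a 1.2-fold lower number from compound 1 to compound 4 (0.08 log units; within the scatter)) or 4-chlorophenyl (a 1.4-fold higher number from compound 3 to compound 4 (0.14 log units; within the scatter)), while 2-chlorophenyl remains the clear outlier among the four (a 6.0-fold lower number from compound 2 to compound 4 (0.78 log units; beyond the scatter)). So compound 1, compound 3 and compound 4 form one group despite their different rings, compound 2 goes against that grouping, and nothing available explains either observation.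

The compounds shown leave open whether other five- or six-membered rings, such as furan-2-yl or pyridin-2-yl, would join that group, and whether a thiophen-2-yl ring carrying chloro would stay with it. They also leave open whether the high number of compound 2 belongs to chloro alone or would also appear with a 2-methylphenyl, 2-methoxyphenyl or 2-aminophenyl group in the same place.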